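Methyl to Methoxy: One Small Exchange on an Aromatic Carbon

The source may report more compounds than this note shows. Statements on the series, on what has been measured and on what is new or still open speak of the compounds shown alone.

Compound 1 `COc1nc(-c2cc3ccccc3o2)cc(-c2ccc(F)cc2)c1C#N`: 321000 nM
Compound 2 `COc1nc(-c2cc3ccccc3o2)cc(-c2ccc(C)cc2)c1C#N`: 266000 nM

In a functional assay on aorta (strain Wistar) for inhibition, with Thoracic aorta (Rattus norvegicus) as the target (a higher number here means a weaker inhibitor, a lower number a stronger inhibitor), compound 2 gives the lower of the two numbers, but the gap to compound 1 is within the scatter, as a 1.2-fold lower number from compound 1 to compound 2 (0.08 log units; within the scatter) shows. Compound 3 `COc1ccc(-c2cc(-c3cc4ccccc4o3)nc(OC)c2C#N)cc1` differs from compound 2 by methoxy in place of methyl on an aromatic carbon. Among the measured compounds shown here, the single measured step, a 1.2-fold lower number from compound 1 to compound 2 (0.08 log units; within the scatter), also swaps one small group for another on that same aromatic carbon and stays within the scatter. The expected step for compound 3 is therefore a 1.1-fold lower number from compound 2 to compound 3 (0.03 log units; within the scatter), none beyond the scatter. Compound 3 is estimated at 250000 nM, ranging from 110000 nM to 550000 nM.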

Compound 3, half-maximal inhibitory concentration: 262000 nM
The estimate for compound 3 lay 1.0-fold (0.02 log units) below the measured number; measured number inside the range.
By their numbers in this assay, from the lowest: compounds 3, 2 and 1 (each within the scatter of the next).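

In this assay methoxy, which brings an oxygen and a hydrogen-bond acceptor to this aromatic carbon where methyl has none, leaves the number within the scatter (a 1.0-fold lower number from compound 2 to compound 3 (0.01 log units; within the scatter)). The same holds against fluoro (a 1.2-fold lower number from compound 1 to compound 3 (0.09 log units; within the scatter)), so fluoro, methyl and methoxy on this carbon cannot be told apart in this read-out. Nothing available here offers an explanation for this. On these data alone, whether an amine or a carboxylic acid on this carbon would move the number stays open. So does whether these three groups would stay as close at another place on the ring.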